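From 4-fluorobenzyl to 4-methylbenzyl: a step expected to stay small

The source may report more compounds than this note shows. Statements on the series, on what has been measured and on what is new or still open speak of the compounds shown alone.

In a functional assay on RS4-11 cells (Homo sapiens) for inhibition, read by CCK-8 assay, with a stated time of 48 h, tested at 20 uM (a higher number here means more inhibition of growth at the concentration tested, a lower number less inhibition of growth), compound 1 (`Cc1ccc(S(=O)(=O)Oc2ccccc2/C=C(\C#N)C(=O)Nc2nnc(Cc3cccc4ccccc34)s2)cc1`) gives 73% inhibition, compound 2 (`Cc1ccc(S(=O)(=O)Oc2ccccc2/C=C(\C#N)C(=O)Nc2nnc(Cc3ccccc3)s2)cc1`) gives 69% inhibition and compound 3 (`Cc1ccc(S(=O)(=O)Oc2ccccc2/C=C(\C#N)C(=O)Nc2nnc(Cc3ccc(F)cc3)s2)cc1`) gives 72% inhibition. Compound 3 stands within the scatter of both other compounds, as the steps of a number 1 percentage points lower from compound 1 to compound 3 (within the scatter) and a number 3 percentage points higher from compound 2 to compound 3 (within the scatter) show.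

Compound 4 (`Cc1ccc(Cc2nnc(NC(=O)/C(C#N)=C/c3ccccc3OS(=O)(=O)c3ccc(C)cc3)s2)cc1`) carries methyl in place of fluoro on an aromatic carbon, para to a large group (methyl in place of fluoro on an aromatic carbon). Among the measured compounds shown here, no measured compound has this methyl, so the evidence is indirect. The closest step is the one at the same place, a number 3 percentage points higher from compound 2 to compound 3 (within the scatter), where fluoro replaces hydrogen. The exchange of the whole aromatic group points the same way, with a number 4 percentage points lower from compound 1 to compound 2 (within the scatter) as its size. Since neither step leaves the scatter, no step beyond the scatter is expected in this assay and no direction can be argued. The estimated change is a number 1 percentage points lower from compound 3 to compound 4 (within the scatter) and it should be read as no real change. For compound 4 the estimate is 71% with an expected range of 62% to 80% for the coming measurement.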

Compound 4, percent growth inhibition at one concentration: 66%
Estimate against measurement, compound 4: 5 percentage points above; the measured number falls inside the stated range.
By their numbers in this assay, from the lowest: compounds 4, 2, 3 and 1 (each within the scatter of the next).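

At this place, on an aromatic carbon para to a large group, methyl now stands alongside hydrogen and fluoro. In this assay, the exchange of fluoro for methyl gives a number 6 percentage points lower from compound 3 to compound 4 (within the scatter) and the addition of methyl in place of hydrogen gives a number 3 percentage points lower from compound 2 to compound 4 (within the scatter), so the three groups cannot be told apart here. Even the widest step in the series, a number 7 percentage points lower from compound 1 to compound 4 (within the scatter), which exchanges naphthalen-1-yl for 4-methylphenyl, does not leave the scatter, and nothing available accounts for the small differences among the four compounds.

From the compounds shown here alone, whether an amine, a hydroxyl, a methoxy or a longer chain at this same place would give a step beyond the scatter remains open. Percent inhibition at a single concentration also leaves open whether these four compounds would separate across a full concentration range.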